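Oxadiazole Acylhydrazones on Gastric Cancer Cells: Toward a Chlorophenol Analogue

The source may hold more compounds than are shown below. What is called first, only, known or untested is meant among the compounds shown, and "the series" means these compounds.

Measured compounds:
Compound 1 `O=C(CSc1nnc(-c2ccncc2)o1)N/N=C/c1ccccc1`: 22100 nM
Compound 2 `O=C(CSc1nnc(-c2ccncc2)o1)N/N=C/c1ccc([N+](=O)[O-])cc1`: 31500 nM

In a functional assay on BGC-823 cells (Homo sapiens) for cytotoxicity, read by MTT assay, with a stated time of 48 h (a lower number here means a stronger inhibitor, a higher number a weaker inhibitor), compound 2 gives 31500 nM, the highest of the two numbers; its nearest neighbour is compound 1 with 22100 nM, and the step of a 1.4-fold higher number from compound 1 to compound 2 (0.15 log units; within the scatter) lies within the scatter. Compound 3 `O=C(CSc1nnc(-c2ccncc2)o1)N/N=C/c1cc(Cl)cc(Cl)c1O` has not yet been measured in this assay. It differs from compound 2 as follows: 3,5-dichloro-2-hydroxyphenyl in place of 4-nitrophenyl on a carbon with a double bond to nitrogen. Within the data shown here, only one measured step exists, a 1.4-fold higher number from compound 1 to compound 2 (0.15 log units; within the scatter), and it concerns a different change on the same ring, so it bears on the present step only loosely. With nothing beyond the scatter in the available data, compound 3 is expected to land near compound 2, with an expected step of a 1.4-fold lower number from compound 2 to compound 3 (0.16 log units; within the scatter), that is, none beyond the scatter. The estimate for compound 3 in this assay is 22000 nM, in a range from 7000 nM to 65000 nM.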

Compound 3, half-maximal inhibitory concentration: 6340 nM
Compound 3: middle estimate off by 3.5-fold (0.54 log units), on the high side; measured number below the stated range.
By their numbers in this assay, from the lowest: compound 3; then compounds 1 and 2 (each within the scatter of the next).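

In this assay the aryl group on the carbon with a double bond to nitrogen now moves the number beyond the scatter, which the change from phenyl to 4-nitrophenyl had not shown: 3,5-dichloro-2-hydroxyphenyl gives a 5.0-fold lower number from compound 2 to compound 3 (0.70 log units; beyond the scatter) and a 3.5-fold lower number from compound 1 to compound 3 (0.54 log units; beyond the scatter). The gain holds against both earlier aryl groups, so it does not depend on which of them serves as the reference. No measurement here says why this replacement lowers the number.

The replacement brings in the hydroxyl and the chlorines together, so the compounds shown cannot divide the gain between them. They also leave open whether an amine or a carboxylic acid in place of the hydroxyl would keep it.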